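Predicting a cyclopropyl aryl swap in an orphan receptor series

The compounds below may be only part of what the source reports. "The series", "measured", "known", "first", "only" and "open" are said of these compounds alone.

Compound 1 `CC(C)CCCN(C(=O)[C@@H]1C[C@H]1c1ccccc1)c1ccc(-c2ccccc2)cc1` gives > 100 nM in a functional assay for agonist activity at G protein-coupled receptor 88 (Homo sapiens), read by HTRF and cAMP accumulation (on this read-out higher numbers stand for an effect only at larger amounts of compound and lower numbers for an effect already at smaller amounts), a limit of the assay.
Compound 2 `CC(C)C[C@H](N)CCN(C(=O)[C@@H]1C[C@H]1c1ccccc1)c1ccc(-c2ccccc2)cc1` gives 3 nM in this assay.
Compound 3 `CC[C@H](C)[C@H](N)CN(C(=O)[C@@H]1C[C@H]1c1ccccc1Cl)c1ccc(-c2ccccc2)cc1` gives > 25000 nM in this assay, again a limit of the assay.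

Compound 3 therefore stands at the weak end of the three values shown, and only as a limit (the limit of > 25000 nM in this assay, at which 1 of the 3 values shown sits), so no number is known for it. Compound 4 `CC[C@H](C)[C@H](N)CN(C(=O)[C@@H]1C[C@H]1c1cccc(C)c1)c1ccc(-c2ccccc2)cc1` differs from compound 3 by 3-methylphenyl in place of 2-chlorophenyl on a saturated ring carbon. Within the data shown here, only one step between measured compounds is available, an at least 33-fold lower number from compound 1 to compound 2 (1.52 log units; beyond the scatter), and it concerns the amine on the chain, not the aryl group on the cyclopropane; it does not bear on the change from compound 3 to compound 4. Compound 1 also sits at a limit (the limit of > 100 nM in this assay, at which 1 of the 3 values shown sits). Among the measured compounds shown here, no measured pair isolates the aryl substituent, so the size and direction of the step cannot be read from the data. Compound 4 is estimated to remain weak, at 10000 nM with a range from 500 nM to 50000 nM, which means an expected step of an at least 2.5-fold lower number from compound 3 to compound 4 (0.39 log units; beyond the scatter) that is stated with little confidence.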

Compound 4, half-maximal effective concentration: 1200 nM
Estimate against measurement, compound 4: 8.3-fold (0.92 log units) above; measured number inside the range.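

The swap of 2-chlorophenyl for 3-methylphenyl on a saturated ring carbon of the three-membered ring shows that the aryl group at this position can by itself move the read-out in this assay, with an at least 20-fold lower number from compound 3 to compound 4 (1.31 log units; beyond the scatter). The earlier step concerned only the amine on the chain, whereas here the chain and the rest of the core stay the same, and compound 4 gives a number, 1200 nM. The value of compound 3 is a limit and not a number, so the real size of this step remains unknown beyond the printed bound: the limit of > 25000 nM in this assay, at which 1 of the 4 values shown sits.

Both the substituent and its place on the phenyl ring change in this one pair, so the compounds shown do not tell whether the step follows from losing the chlorine, gaining the methyl or the change of place; a 3-chlorophenyl or a 2-methylphenyl group on the same core would separate these. From the compounds shown here alone, it also remains open how an unsubstituted phenyl group would read out with the chain of compound 3 and compound 4, and whether a larger group such as 3-ethylphenyl would be accepted at this position.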